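The source may hold more compounds than are shown below. What is called first, only, known or untested is meant among the compounds shown, and "the series" means these compounds.

Measured compounds:
compound 1 `Cc1nn(C)c2nc(NNC(=O)Nc3cc(Cl)nc(Cl)c3)cc(-c3ccc(Cl)s3)c12` — 42100 nM
compound 2 `COc1cc(NC(=O)NNc2cc(-c3ccc(F)cc3)c3cnn(C)c3n2)cc(Cl)n1` — 75300 nM

In a functional assay on HCT-116 cells (Homo sapiens) for cytotoxicity, read by MTT assay, with a stated time of 48 h, in the presence of a further agent that is not named here (on this read-out lower numbers stand for an effect already at smaller amounts and higher numbers for an effect only at larger amounts of compound), compound 1 gives 42100 nM and compound 2 gives 75300 nM; both numbers lie within the scatter of each other, so no order can be read between them. Compound 1 has the lowest of the two numbers shown, with compound 2 nearest.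

Compound 3 `Cc1nn(C)c2nc(NNC(=O)Nc3cc(Cl)nc(Cl)c3)cc(C3CCCCC3)c12` is not yet measured. It differs from compound 1 by cyclohexyl in place of 5-chlorothiophen-2-yl on an aromatic carbon. Among the measured compounds shown here, no step between measured compounds covers a change of this kind, so no size can be drawn from the data. The step from compound 1 to compound 3 in this assay is expected to be small, a 1.4-fold higher number from compound 1 to compound 3 (0.15 log units; within the scatter), and may not exceed the scatter. For compound 3 the expected value in this assay is 60000 nM, within 20000 nM to 200000 nM.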

Compound 3, half-maximal effective concentration: 38000 nM
Beside the measured number, compound 3's estimate is 1.6-fold (0.20 log units) above it; low and high end bracket the measured number.
By their numbers in this assay, from the lowest: compounds 3, 1 and 2 (each within the scatter of the next).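

In this assay, the swap of 5-chlorothiophen-2-yl for cyclohexyl on this aromatic carbon, opposite the ring nitrogen, gives a 1.1-fold lower number from compound 1 to compound 3 (0.04 log units; within the scatter) and so stays within the scatter. The earlier compounds shown here gave no step at this position; this one shows that an aromatic ring with sulfur and chlorine and a non-aromatic ring of carbon only cannot be told apart here. No measurement at hand speaks to the reason.

Going by these compounds, an amine, a carboxylic acid or a longer alkyl chain at this position remains open, as does whether any group here moves the number beyond the scatter.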